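Second chloro on the aryl ring of compound 3

The source may hold more compounds than are shown below. What is called first, only, known or untested is meant among the compounds shown, and "the series" means these compounds.

Measured so far:
Compound 1, `CCc1nnc2sc(-c3c[nH]nc3-c3ccc(F)cc3)nn12`, gives 23.5% in a functional assay on the whole organism (strain Wistar) for inhibition, with Rattus norvegicus as the target, read by paw edema, with stated times of 30 min and 2.5 h, at a dose of 20 mg/kg by the intraperitoneal route; a higher number here means more inhibition at the dose given (going by the name of the read-out), a lower number less inhibition.
Compound 2, `CCc1nnc2sc(-c3c[nH]nc3-c3ccc(OC)cc3)nn12`, gives 17.6% in this assay.
Compound 3, `CCc1nnc2sc(-c3c[nH]nc3-c3ccc(Cl)cc3)nn12`, gives 56.9% in this assay.

Compound 3 stands highest of the three numbers in this assay. Both steps leading to it, a number 33.4 percentage points higher from compound 1 to compound 3 (beyond the scatter) and a number 39.3 percentage points higher from compound 2 to compound 3 (beyond the scatter), lie beyond the scatter, so compound 3 has the highest number of the measured set. The remaining step, a number 5.9 percentage points lower from compound 1 to compound 2 (within the scatter), lies within the scatter, so compound 1 and compound 2 cannot be ordered.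

Compound 4, `CCc1nnc2sc(-c3c[nH]nc3-c3ccc(Cl)cc3Cl)nn12`, is not yet measured in this assay. Relative to compound 3 the change is chloro in place of hydrogen on an aromatic carbon; the entering chloro sits ortho to a large group and meta to the chloro group already present.

Among the compounds with values here, the steps that bear on this are a number 33.4 percentage points higher from compound 1 to compound 3 (beyond the scatter) and a number 39.3 percentage points higher from compound 2 to compound 3 (beyond the scatter), both large, which show that a chloro on this ring goes with a high number in this assay. Within the data shown here, no measured step, however, adds a group to a carbon that bore hydrogen, so the second chloro has no direct precedent. Compound 4 is therefore expected to hold roughly the level of compound 3, with an estimated step of a number 1.1 percentage points higher from compound 3 to compound 4 (within the scatter) that need not exceed the scatter. Compound 4 is estimated at 58%, in a range from 35% to 78%.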

Compound 4, a percentage reported as inhibition, in the whole organism at one dose (the size of the read-out at that dose, not a potency): 25.5%
Estimate against measurement, compound 4: 32.5 percentage points above; measured number below the stated range.
By their numbers in this assay, from the lowest: compounds 2, 1 and 4 (each within the scatter of the next); then compound 3.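

Chloro in place of hydrogen on the carbon ortho to a large group goes with a number 31.4 percentage points lower from compound 3 to compound 4 (beyond the scatter) in this assay, so this carbon of the aryl ring is not a neutral place for an added group in this series. Within the data shown here, the earlier steps only exchanged one group for another at a single place on the ring, whereas this is the first step that adds a group to a carbon bearing hydrogen. It also narrows the earlier reading: compound 4 keeps the chloro group of compound 3, so that chloro alone does not secure a high number in this assay. Nothing measured on these compounds accounts for the drop, and the step stands as an observation only.

The compounds shown leave open whether the drop belongs to chloro itself or to any group at this carbon, a question that a methyl or a hydroxyl there would address. They also leave open whether the same carbon behaves alike when the chloro group meta to it is absent, and how a longer chain in place of the ethyl on the core would read.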